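The compounds below may be only part of what the source reports. "The series", "measured", "known", "first", "only" and "open" are said of these compounds alone.

Measured so far:
- compound 1 `CNC(=O)c1cc(Oc2ccc(C3=NNC(c4cccc(Br)c4)C3)cc2)ccn1`: 2840 nM
- compound 2 `CNC(=O)c1cc(Oc2ccc(C3=NNC(c4cccc([N+](=O)[O-])c4)C3)cc2)ccn1`: "not determined" (no result reported)
- compound 3 `CNC(=O)c1cc(Oc2ccc(C3=NNC(c4ccc(OC)cc4)C3)cc2)ccn1`: 13100 nM

In a functional assay on A549 cells (Homo sapiens) for cytotoxicity, read by MTT assay, with a stated time of 72 h (a lower number here means a stronger inhibitor, a higher number a weaker inhibitor), compound 3 gives 13100 nM, the higher of the two numbers available, while compound 2 has no number to compare. Compound 4 `CNC(=O)c1cc(Oc2ccc(C3=NNC(c4ccccc4)C3)cc2)ccn1` differs from compound 3 by hydrogen in place of methoxy on an aromatic carbon, para to a large group: hydrogen in place of methoxy on an aromatic carbon.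

Among the compounds with values here, only one measured step bears on this change: a 4.6-fold higher number from compound 1 to compound 3 (0.66 log units; beyond the scatter). It is modest, with 4-methoxyphenyl in place of 3-bromophenyl on a saturated ring carbon. Within the data shown here, that step swaps two groups at once, and no measured pair isolates the loss of methoxy, so it is only a loose guide. Compound 4 is expected to fall near or within the span set by compound 1 and compound 3. The expected change is small, towards a lower number, and may not clear the scatter: a 1.9-fold lower number from compound 3 to compound 4 (0.27 log units; within the scatter). For compound 4 the estimate is 7000 nM, with an expected range of 2500 nM to 18000 nM.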

Compound 4, half-maximal inhibitory concentration: 8600 nM
Compound 4: the middle estimate sits 1.2-fold (0.09 log units) below what was measured; low and high end bracket the measured number.
By their numbers in this assay, from the lowest: compound 1; then compounds 4 and 3 (each within the scatter of the next).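

In this assay, the methoxy group on the phenyl ring proves dispensable: taking it away leaves the number within the scatter (a 1.5-fold lower number from compound 3 to compound 4 (0.18 log units; within the scatter)). Hydrogen in place of bromo gives a clearer step, beyond the scatter (a 3.0-fold higher number from compound 1 to compound 4 (0.48 log units; beyond the scatter)), so the 3-bromophenyl group of compound 1 stands apart from the plain phenyl group of compound 4, while the 4-methoxyphenyl group of compound 3 does not. No measurement shown explains this difference between the two groups.

On these data alone, with only these two readable groups, it remains open whether bromo itself or its place on the ring sets compound 1 apart, since compound 2 has no number. As far as these compounds go, it is also open how an amine or a carboxylic acid on this phenyl ring would compare.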